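The source may report more compounds than this note shows. Statements on the series, on what has been measured and on what is new or still open speak of the compounds shown alone.

Two members of this series have so far been run in a functional assay on Urethra for agonist activity at Alpha-1A adrenergic receptor (Oryctolagus cuniculus); on this read-out lower numbers stand for lower potency and higher numbers for higher potency (the scale is a negative logarithm). Compound 1 `CS(=O)(=O)Nc1c(O)ccc2c1CCCC2c1c[nH]cn1` gives 7.77 in this assay. Compound 2 `Cn1cnc(C2CCCc3c(NS(C)(=O)=O)cccc32)c1` gives 5.26 in this assay, the lower of the two numbers, and compound 1 stands above it by a gap beyond the usual scatter. Compound 3 `CS(=O)(=O)Nc1cccc2c1CCCC2C1=NCCN1` has not yet been run. It differs from compound 2 in one place: a group of 5 heavy atoms (3 carbon, 2 nitrogen; one five-membered non-aromatic ring with 2 hetero atoms) in place of a group of 6 heavy atoms (4 carbon, 2 nitrogen; one five-membered aromatic ring with 2 hetero atoms), on a saturated ring carbon. The entering ring is non-aromatic where the leaving ring was aromatic. For the measured compounds named here, no measured pair shows this exact change, so the size of the step rests on the two numbers alone, with compound 1 as the upper reference of the series. The step is expected to raise potency in this assay, by a number 1.54 log units higher from compound 2 to compound 3 (beyond the scatter) as estimated here. Compound 3 is estimated at 6.8, with a range of 5.8 to 7.8.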

Compound 3, negative logarithm of the half-maximal effective concentration: 6.19
The estimate for compound 3 lay 0.61 log units above the measured number; low and high end bracket the measured number.
By their numbers in this assay, from the lowest: compound 2; then compound 3; then compound 1.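

On the saturated ring carbon, replacing 1-methyl-1H-imidazol-4-yl with the five-membered non-aromatic ring gives a number 0.93 log units higher from compound 2 to compound 3 (beyond the scatter) in this assay; this is the only one-place step shown, and it establishes that the ring at this carbon affects the read-out. The change alters several counted features at once: the ring is no longer aromatic, the entering group has 1 hydrogen-bond donor where the leaving group has 0, and it has one heavy atom fewer, so this step cannot separate their contributions. No available evidence accounts for the size of the step.

From the compounds shown here alone, whether another group at this carbon, such as an oxazoline ring or an aminomethyl chain, would match or exceed this step remains open. Also open, going by these compounds, is whether the same change would give a similar step on the core of compound 1.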